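From Compound 2 to Compound 3: Exposure in Mice

A few compounds are considered here, and "the series" means these few. Any claim that something is new, unique, unknown or untested is made for them only; others in the source may bear on it.

Compound 2 `O=C(Nc1ccc(F)c(-c2nc3ncc(-c4cccnc4F)cc3[nH]2)c1)N1CCCC1` gives 30900 ng.h/mL in an ADME assay on the whole organism (Mus musculus, strain Swiss Webster) for pharmacokinetics, read by LC-MS, at a dose of 50 mg/kg by the oral route (a lower number here means less compound in the circulation, a higher number more compound in the circulation at the dose given), the highest of the two numbers measured, with compound 1 `O=C(Nc1ccc(F)c(-c2nc3ncc(-c4ccc(F)c(F)c4)cc3[nH]2)c1)N1CCCC1` the nearest at 12000 ng.h/mL. Compound 3 `O=C(Nc1ccc(F)c(-c2nc3ncc(-c4ccccc4F)cc3[nH]2)c1)N1CCCC1` differs from compound 2 in one place: 2-fluorophenyl in place of 2-fluoropyridin-3-yl on an aromatic carbon. Going by the values given here, the only step measured so far, a 2.6-fold higher number from compound 1 to compound 2 (0.41 log units; beyond the scatter), concerned the same position and ran toward the 2-fluoropyridin-3-yl group; the present change, back to a six-membered aromatic ring of carbon only, is expected to lower the number, by about a 2.1-fold lower number from compound 2 to compound 3 (0.31 log units; beyond the scatter). Compound 3 is therefore estimated at 15000 ng.h/mL, with a range of 6000 ng.h/mL to 40000 ng.h/mL.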

Compound 3, area under the concentration-time curve: 4870 ng.h/mL
The estimate for compound 3 lay 3.1-fold (0.49 log units) above the measured number; the whole stated range lies above it.
By their numbers in this assay, from the lowest: compound 3; then compound 1; then compound 2.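

In this assay, the 2-fluoropyridin-3-yl group now stands out at this position from both carbon-only rings: a 6.3-fold lower number from compound 2 to compound 3 (0.80 log units; beyond the scatter) exceeds the earlier gain of a 2.6-fold higher number from compound 1 to compound 2 (0.41 log units; beyond the scatter). The two carbon-only rings also differ from each other, with a 2.5-fold lower number from compound 1 to compound 3 (0.39 log units; beyond the scatter), so the number here depends on more than the ring nitrogen. No measurement on hand accounts for these differences.

On these data alone, whether the ring nitrogen would carry the higher number without its fluorine remains open, as does the effect of an amine or a methoxy group on the pyridine ring.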